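A few compounds are considered here, and "the series" means these few. Any claim that something is new, unique, unknown or untested is made for them only; others in the source may bear on it.

Compound 1 `NC(=O)CCCCc1c[nH]c2ccc(F)cc12`: 39 nM
Compound 2 `NCCSCCCc1c[nH]c2c(F)cccc12`: > 100 nM

In an assay on isolated protein (urine) for inhibition of Myeloperoxidase (Homo sapiens), with a stated time of 5 min (a higher number here means a weaker inhibitor, a lower number a stronger inhibitor), compound 1 gives 39 nM, the only actual number among the two results shown. Compound 2 reaches only (the limit of > 100 nM in this assay, at which 1 of the 2 values shown sits), which is a limit of the assay rather than a number. Among the compounds with values here, no step between two measured compounds can be read from this pair. Compound 3 `CCSCCc1c[nH]c2ccc(F)cc12` keeps the core of compound 1 and differs from it by ethylsulfanyl in place of 2-carbamoylethyl on a saturated chain carbon, two bonds along the chain from an aromatic carbon. The step is expected to be modest and toward weaker inhibition, close to the scatter of repeated measurements, as a 3.1-fold higher number from compound 1 to compound 3 (0.49 log units; beyond the scatter). Compound 3 is therefore estimated at 120 nM, expected to fall between 40 nM and 400 nM.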

Compound 3, half-maximal inhibitory concentration: > 100 nM
Compound 3: a limit, no number (the forecaster's own chance of this, stated with the estimate: 45%); the middle value lies beyond the limit too.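

In this assay, ethylsulfanyl in place of 2-carbamoylethyl on a saturated chain carbon, two bonds along the chain from an aromatic carbon, gives an at least 2.5-fold higher number from compound 1 to compound 3 (0.40 log units; beyond the scatter), so on the shared core the group at this place moves the read-out beyond the scatter. The value of compound 3 is a limit and not a number, so the step has only a lower bound: the limit of > 100 nM in this assay, at which 2 of the 3 values shown sit.

From the compounds shown here alone, whether the weakening goes with the loss of the carbonyl and the amide hydrogen or with the entry of sulfur stays open. So does the effect of a carboxylic acid or a plain alkyl chain at this place.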